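The source may report more compounds than this note shows. Statements on the series, on what has been measured and on what is new or still open speak of the compounds shown alone.

Three measured compounds share one core and differ only in the aryl group on an amine nitrogen in a ring. Compound 1 `CC1CC(=O)N(CC(=O)N2CCN(c3ccc(Cl)cc3)CC2)C1=O` gives 100 mg/kg in a functional assay on the whole organism (strain CD1) with Mus musculus as the target, in the maximal electroshock model, with a stated time of 0.5 h; a higher number here means that more compound is needed for the effect, a lower number that less compound is needed. Compound 2 `CC1CC(=O)N(CC(=O)N2CCN(c3cccc(Cl)c3)CC2)C1=O` gives 100 mg/kg in this assay. Compound 3 `Cc1ccccc1N1CCN(C(=O)CN2C(=O)CC(C)C2=O)CC1` gives 300 mg/kg in this assay. Compound 3 therefore stands at the highest of the three numbers: the step of a 3.0-fold higher number from compound 1 to compound 3 (0.48 log units; beyond the scatter) and the step of a 3.0-fold higher number from compound 2 to compound 3 (0.48 log units; beyond the scatter) both lie beyond the scatter, whereas the step of no change at the digits printed from compound 1 to compound 2 (within the scatter) does not.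

Compound 4 `CC1CC(=O)N(CC(=O)N2CCN(c3ccccc3F)CC2)C1=O` differs from compound 3 by fluoro in place of methyl on an aromatic carbon. Among the compounds with values here, no measured step exchanges fluoro for methyl, and none places a second group on the 2-methylphenyl ring, so the only steps that bear on the question are the two leading into compound 3, a 3.0-fold higher number from compound 1 to compound 3 (0.48 log units; beyond the scatter) and a 3.0-fold higher number from compound 2 to compound 3 (0.48 log units; beyond the scatter), which show that a halogen-bearing aryl group reaches a lower number than 2-methylphenyl in the two cases measured. On that basis a modest step towards a lower number is expected for compound 4, with wide uncertainty, estimated as a 2.0-fold lower number from compound 3 to compound 4 (0.30 log units; within the scatter) in this assay. Compound 4 is accordingly expected to give about 150 mg/kg in this assay, estimated to fall between 60 mg/kg and 300 mg/kg.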

Compound 4, minimum effective dose: 300 mg/kg
For compound 4 the middle estimate is 2.0-fold (0.30 log units) below the measured one; the measured number falls inside the stated range.
By their numbers in this assay, from the lowest: compounds 1 and 2 (each within the scatter of the next); then compounds 3 and 4 (each within the scatter of the next).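

With fluoro in place of methyl on the aromatic carbon ortho to a large group, the result in this assay is no change at the digits printed from compound 3 to compound 4 (within the scatter), so at this position the two groups cannot be told apart. A halogen on the aryl group is also not enough for the lower number, as compound 4 carries fluoro and yet the steps are a 3.0-fold higher number from compound 2 to compound 4 (0.48 log units; beyond the scatter) and a 3.0-fold higher number from compound 1 to compound 4 (0.48 log units; beyond the scatter); among these four compounds, the 2-methylphenyl and 2-fluorophenyl groups share the higher number, while the 3-chlorophenyl and 4-chlorophenyl groups share the lower one, with no compound going against this split. No supporting data are available to explain why these groups fall into these two sets.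

The compounds shown leave open whether the split follows the place of the group on the ring or the identity of the halogen, a question that chloro in place of the fluoro of compound 4 would address. They also leave open how an unsubstituted phenyl group or a methoxy group on the same ring would read in this assay.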